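This account rests on a few compounds, and the source may have more. Where it says the series, first, only, none or still open, it means among the compounds named here.

Working notes on the series, all values from a functional assay on MDA-MB-231 cells (Homo sapiens) for antiproliferative activity, with a stated time of 4 days; on this read-out higher numbers stand for weaker inhibition and lower numbers for stronger inhibition:

- compound 1 `CCCCc1ccc2[nH]c(-c3ccc(OC)cc3)c(/C=N/NC(=O)c3ccc(Cl)cc3)c2c1`: 90 nM
- compound 2 `CCCCc1ccc2[nH]c(-c3ccc(C(F)(F)F)cc3)c(/C=N/NC(=O)c3ccc(Cl)cc3)c2c1`: 329 nM
- compound 3 `CCCCc1ccc2[nH]c(-c3ccc(OC)cc3)c(/C=N/NC(=O)c3cccc(OC)c3)c2c1`: 55 nM

Compound 2 has the highest number of the three and is the weakest inhibitor in this small set. The next step leads to compound 4 `CCCCc1ccc2[nH]c(-c3ccc(C(F)(F)F)cc3)c(/C=N/NC(=O)c3cccnc3)c2c1`, still unmeasured, and the change is pyridin-3-yl in place of 4-chlorophenyl on a carbonyl carbon. In words, pyridin-3-yl stands in place of 4-chlorophenyl on a carbonyl carbon, while the trifluoromethyl group stays.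

Among the compounds with values here, only one measured step falls at this place: a 1.6-fold lower number from compound 1 to compound 3 (0.21 log units; within the scatter). It brings in 3-methoxyphenyl rather than pyridin-3-yl, and it was measured with methoxy, not trifluoromethyl, in the rest of the molecule. It therefore offers only indirect guidance. The other measured step, a 3.7-fold higher number from compound 1 to compound 2 (0.56 log units; beyond the scatter), lies at an aromatic carbon elsewhere in the molecule. It does not bear directly on this change.

On these data alone, no step beyond the scatter is therefore expected, and the direction remains open. The expected change is a 1.2-fold higher number from compound 2 to compound 4 (0.08 log units; within the scatter). For compound 4 the estimated value in this assay is 400 nM, with an expected range of 150 nM to 1100 nM.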

Compound 4, half-maximal inhibitory concentration: 97 nM
Estimate against measurement, compound 4: 4.1-fold (0.62 log units) above, outside the stated range (below it).
By their numbers in this assay, from the lowest: compounds 3, 1 and 4 (each within the scatter of the next); then compound 2.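

In this assay, within the data shown here, the carbonyl carbon proves able to carry a step beyond the scatter, a 3.4-fold lower number from compound 2 to compound 4 (0.53 log units; beyond the scatter), whereas the only earlier step at this place, a 1.6-fold lower number from compound 1 to compound 3 (0.21 log units; within the scatter), stayed within it. The new step also shows that, with trifluoromethyl held in the rest of the molecule, 4-chlorophenyl can be replaced by pyridin-3-yl, a ring with a hetero atom and a hydrogen-bond acceptor, without any loss on this read-out; the two steps differ in both the entering group and the rest of the molecule, so neither difference alone can be credited with the contrast. No measurement at hand accounts for the lower number of compound 4, and the reason for the step remains unexplained.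

The compounds shown leave open whether pyridin-3-yl gives a similar step when methoxy replaces trifluoromethyl, and whether 3-methoxyphenyl behaves differently with trifluoromethyl in place. They also leave open whether the step depends on the ring nitrogen or on the loss of chlorine, a question that a plain phenyl group at the carbonyl carbon would address, while a ring bearing an amine or a carboxylic acid would test quite different chemistry there.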